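Working notes: compound 1 to compound 4

A few compounds are considered here, and "the series" means these few. Any claim that something is new, unique, unknown or untested is made for them only; others in the source may bear on it.

Three compounds of the series have numbers in a functional assay on CHO cells for antagonist activity at Glucagon receptor (Homo sapiens), read by cAMP accumulation, with stated times of 30 min and 45 min; a lower number here means a stronger inhibitor, a higher number a weaker inhibitor. Compound 1 `C[C@H](c1ccc(C(=O)NCCC(=O)O)cc1)N1C(=O)C(c2cccc(C3CC3)c2)=N[C@]12CC[C@@H](C(C)(C)C)CC2` gives 340 nM in this assay. Compound 3 `CC1(CC[C@H](c2ccc(C(=O)NCc3nn[nH]n3)cc2)N2C(=O)C(c3cc(Cl)cc(Cl)c3)=N[C@]23CC[C@@H](C(C)(C)C)CC3)CC1` gives 100 nM, and compound 2 `CC(C)(C)CC[C@H](c1ccc(C(=O)NCCS(=O)(=O)O)cc1)N1C(=O)C(c2cc(Cl)cc(Cl)c2)=N[C@]12CC[C@@H](C(C)(C)C)CC2` gives 8500 nM. Compound 1 thus stands second highest of the three; its nearest neighbour is compound 3, a gap beyond the scatter, and its furthest is compound 2, a gap far beyond the scatter. Compounds 2 and 3 each differ from compound 1 in several places at once, so neither pair isolates a single change.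

Compound 4 `C[C@H](c1ccc(C(=O)NCCC(=O)O)cc1)N1C(=O)C(c2cccc(OC(F)(F)F)c2)=N[C@]12CC[C@@H](C(C)(C)C)CC2` differs from compound 1 in one place: trifluoromethoxy in place of cyclopropyl on an aromatic carbon. Among the measured compounds shown here, no measured pair isolates this change, so no step of this kind is known here, and the expectation rests on compound 1 alone, whose value of 340 nM is the anchor. The step from compound 1 to compound 4 is expected to be small, a 1.3-fold higher number from compound 1 to compound 4 (0.12 log units; within the scatter), at or just beyond the scatter and leaning to a weaker inhibitor. Compound 4 is therefore estimated at 450 nM in this assay, with a range of 150 nM to 1300 nM.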

Compound 4, half-maximal inhibitory concentration: 840 nM
Estimate against measurement, compound 4: 1.9-fold (0.27 log units) below; the measured number falls inside the stated range.
By their numbers in this assay, from the lowest: compound 3; then compound 1; then compound 4; then compound 2.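

Among the compounds shown here, compound 4 supplies the first comparison that isolates a single change: in this assay, trifluoromethoxy in place of cyclopropyl on an aromatic carbon, meta to a large group, gives a 2.5-fold higher number from compound 1 to compound 4 (0.39 log units; beyond the scatter). This position therefore responds to the change from 3-cyclopropylphenyl to 3-(trifluoromethoxy)phenyl, but the modest step shows that the larger, ring-free group is accepted with only a limited loss of inhibition. Nothing available bears on the reason for this step.

From the compounds shown here alone, it remains open how a methoxy group, a nitrile or a simple hydrogen would read at this position, and so whether cyclopropyl is better than most groups here or trifluoromethoxy is unusually poor. Going by these compounds, it is also open whether the step would keep its size alongside the different chains of compound 2 and compound 3.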